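Para substituent on the aryl ring: methoxy to methyl

The compounds below may be only part of what the source reports. "The series", "measured", "known", "first", "only" and "open" are said of these compounds alone.

Measured compounds in a functional assay on HeLa cells (Homo sapiens) for cytotoxicity, with a stated time of 72 h; a higher number here means a weaker inhibitor, a lower number a stronger inhibitor:

Compound 1, `Clc1ccc(Cc2nn3c(Br)c(-c4ccc(Cl)cc4)nc3s2)cc1`, sits at a limit of the assay, > 250000 nM, and not at a number.
Compound 2, `Clc1ccc(Cc2nn3c(Br)c(-c4ccc(Br)cc4)nc3s2)cc1`, gives 188000 nM.
Compound 3, `COc1ccc(-c2nc3sc(Cc4ccc(Cl)cc4)nn3c2Br)cc1`, gives 66000 nM.

Compound 3 holds the lowest number of the two numbers recorded in this assay; its nearest neighbour is compound 2, with a 2.8-fold lower number from compound 2 to compound 3 (0.45 log units; beyond the scatter). Against compound 1 the step is an at least 3.7-fold lower number from compound 1 to compound 3 (0.57 log units; beyond the scatter), read from the limit (the limit of > 250000 nM in this assay, at which 1 of the 3 values shown sits).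

Compound 4, `Cc1ccc(-c2nc3sc(Cc4ccc(Cl)cc4)nn3c2Br)cc1`, differs from compound 3 in one place: methyl in place of methoxy on an aromatic carbon. The two measured steps that touch the same carbon are the replacement of chloro and of bromo by methoxy, an at least 3.7-fold lower number from compound 1 to compound 3 (0.57 log units; beyond the scatter) and a 2.8-fold lower number from compound 2 to compound 3 (0.45 log units; beyond the scatter), both lowering the number. The step in the other direction, chloro to bromo, an at least 1.3-fold lower number from compound 1 to compound 2 (0.12 log units; that floor lies within the scatter), has a floor within the scatter. Methyl, like the two halogens, carries no hydrogen-bond acceptor, so the move away from methoxy in this assay is expected to undo part of what methoxy brought, giving a modestly higher number rather than none beyond the scatter. Compound 4 is therefore estimated at 130000 nM, with a range from 50000 nM to 300000 nM, which means an expected step of a 2.0-fold higher number from compound 3 to compound 4 (0.29 log units; within the scatter).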

Compound 4, half-maximal inhibitory concentration: > 250000 nM
Compound 4: only a limit was reported; the forecaster's own chance of this, stated with the estimate: 25%; middle value at least 1.9-fold (0.28 log units) away from the limit.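

In this assay compound 4 gives > 250000 nM, which is a limit of the assay and not a number. Replacing methoxy with methyl gives an at least 3.7-fold higher number from compound 3 to compound 4 (0.57 log units; beyond the scatter), so the lower number seen with methoxy does not carry over to a small carbon-only group, and methoxy now stands apart, beyond the scatter, from all three other groups shown on this carbon. Methyl against bromo gives an at least 1.3-fold higher number from compound 2 to compound 4 (0.12 log units; that floor lies within the scatter), which does not separate the two groups, and the step between compound 1 and compound 4 cannot be read, with both compounds at the same ceiling: the limit of > 250000 nM in this assay, at which 2 of the 4 values shown sit.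

On these data alone, whether the lower number follows the oxygen of methoxy stays open; a hydroxy, ethoxy or dimethylamino group on this carbon would bear on that question. As far as these compounds go, how methyl, chloro and bromo rank against one another also stays open, as does whether the methoxy step holds when the bromo on the shared core or the chlorine of the benzyl group is exchanged for another group.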